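Compound 2 to compound 3: an amide group swapped

The compounds below may be only part of what the source reports. "The series", "measured", "known", "first", "only" and "open" are said of these compounds alone.

In a physicochemical assay for solubility, read by spectrophotometry, measured as kinetic solubility, at pH 8, tested at 500 uM (on this read-out higher numbers stand for higher solubility and lower numbers for lower solubility), compound 1 (`CNS(=O)(=O)c1ccccc1Nc1cc(-c2ccc3ccn(C)c3c2)c2nccnc2c1`) gives 2 ug/mL and compound 2 (`Cn1cc(CNC(=O)c2ccncc2Nc2cc(-c3ccc4ccn(C)c4c3)c3nccnc3c2)cn1`) gives 127 ug/mL, which puts compound 2 higher, by a gap beyond the scatter. Compound 3 (`CN1CCC(NC(=O)c2ccncc2Nc2cc(-c3ccc4ccn(C)c4c3)c3nccnc3c2)CC1=O`) carries 1-methyl-2-oxopiperidin-4-yl in place of (1-methyl-1H-pyrazol-4-yl)methyl on an amide-type nitrogen. Within the data shown here, no measured pair yet shows a single change of this kind. The expected step in this assay is therefore none beyond the scatter, in either direction (a 1.2-fold lower number from compound 2 to compound 3 (0.06 log units; within the scatter)). Compound 3 is estimated at 110 ug/mL, with 40 ug/mL to 230 ug/mL as the expected range.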

Compound 3, solubility: 48 ug/mL
For compound 3 the middle estimate is 2.3-fold (0.36 log units) above the measured one; low and high end bracket the measured number.
By their numbers in this assay, from the lowest: compound 1; then compound 3; then compound 2.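

In this assay, among these compounds, the swap to 1-methyl-2-oxopiperidin-4-yl on the amide-type nitrogen gives a 2.6-fold lower number from compound 2 to compound 3 (0.42 log units; beyond the scatter) and is the first single change read at this place. It shows that the group carried here can move the number, though only modestly. Nothing measured here explains the step.
One swap cannot tell whether the five-membered aromatic ring leaving or the carbonyl-bearing ring entering matters more. Going by these compounds, how an amine such as 1-methylpiperidin-4-yl, or a longer chain ending in a carboxylic acid, would read at this place remains open.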